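The source may hold more compounds than are shown below. What is called first, only, known or untested is meant among the compounds shown, and "the series" means these compounds.

Compound 3 `CC(C)(O)C#Cc1cc(C(O)(C(F)(F)F)C(F)(F)F)cnc1N1CCN(S(=O)(=O)c2ccc(N)nc2)CC1` gives 16 mL.min-1.g-1 in an ADME assay (liver) for metabolic stability, with Liver microsome (Rattus norvegicus) as the target, using microsomes and NADPH, with a stated time of 30 min, tested at 1 uM (a lower number here means slower removal, a higher number faster removal of the compound), the lowest of the three numbers in hand. Compound 1 `Nc1ccc(S(=O)(=O)N2CCN(c3ncc(C(O)(C(F)(F)F)C(F)(F)F)cc3Br)CC2)cn1` gives 32 mL.min-1.g-1, and compound 2 `Nc1ccc(S(=O)(=O)N2CCN(c3ncc(C(O)(C(F)(F)F)C(F)(F)F)cc3C#CCO)CC2)cn1` gives 65 mL.min-1.g-1. The measured steps among them are a 2.0-fold lower number from compound 1 to compound 3 (0.30 log units; within the scatter), a 4.1-fold lower number from compound 2 to compound 3 (0.61 log units; beyond the scatter) and a 2.0-fold higher number from compound 1 to compound 2 (0.31 log units; beyond the scatter). Compound 4 `CS(=O)(=O)c1ccc(-c2cc(C(O)(C(F)(F)F)C(F)(F)F)cnc2N2CCN(S(=O)(=O)c3ccc(N)nc3)CC2)cc1` carries the change (4-(methylsulfonyl)phenyl in place of 3-hydroxy-3-methylbut-1-yn-1-yl on an aromatic carbon). Among the measured compounds shown here, no measured step exchanges the 3-hydroxy-3-methylbut-1-yn-1-yl group for a ring-bearing group; the steps in hand cover only bromo against the two alkynes and hydroxymethyl against 1-hydroxy-1-methylethyl on the triple-bonded carbon, all modest. For compound 4 a step of similar modest size is therefore expected, a 1.6-fold higher number from compound 3 to compound 4 (0.19 log units; within the scatter), its direction only loosely indicated. Compound 4 is estimated at 25 mL.min-1.g-1, with a range from 10 mL.min-1.g-1 to 60 mL.min-1.g-1.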

Compound 4, intrinsic clearance in microsomes: 103 mL.min-1.g-1
The estimate for compound 4 lay 4.1-fold (0.61 log units) below the measured number, outside the stated range (above it).
By their numbers in this assay, from the lowest: compounds 3 and 1 (each within the scatter of the next); then compounds 2 and 4 (each within the scatter of the next).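

Among the compounds shown here, at this position, on an aromatic carbon two atoms from the ring nitrogen, 4-(methylsulfonyl)phenyl gives the first ring-bearing comparison in this assay with a 6.4-fold higher number from compound 3 to compound 4 (0.81 log units; beyond the scatter) and a 3.2-fold higher number from compound 1 to compound 4 (0.51 log units; beyond the scatter) while a 1.6-fold higher number from compound 2 to compound 4 (0.20 log units; within the scatter) shows no separation from the 3-hydroxyprop-1-yn-1-yl group. A group with no triple bond thus groups with compound 2 and not with compound 3. No data here explain this rise.

On these data alone, whether a plain phenyl ring, or a phenyl ring carrying an amine or a carboxylic acid, behaves like compound 4 remains open.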